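Chain extension on the alkoxymethyl arm of the shared core

This account rests on a few compounds, and the source may have more. Where it says the series, first, only, none or still open, it means among the compounds named here.

Three compounds of the shared core carry an alkoxymethyl group on the amine. In a functional assay on PC-3 cells (Homo sapiens) for cytotoxicity, read by MTT assay, with a stated time of 72 h (a higher number here means a weaker inhibitor, a lower number a stronger inhibitor), compound 1 `CCCCOCNc1n[n+]([O-])c2ccccc2[n+]1[O-]` gives 14700 nM, the highest of the three numbers. Compound 2 `COc1ccc2c(c1)[n+]([O-])nc(NCOC(C)c1ccccc1)[n+]2[O-]` gives 4140 nM in this assay, and compound 3 `CC(OCNc1n[n+]([O-])c2ccccc2[n+]1[O-])c1ccccc1` gives 6080 nM in this assay; compound 1 therefore stands beyond the scatter above both, nearer to compound 3 than to compound 2. Going by the values given here, the one paired step, a 1.5-fold higher number from compound 2 to compound 3 (0.17 log units; within the scatter), concerns only the methoxy on the core and stays within the scatter.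

Compound 4 `CCCCCOCNc1n[n+]([O-])c2ccccc2[n+]1[O-]` differs from compound 1 by methyl in place of hydrogen on a saturated chain carbon, four bonds along the chain from an oxygen on a saturated carbon: butyl becomes pentyl. Among the compounds with values here, no measured pair adds a chain carbon, so the step from compound 2 to compound 3 does not bear on this change, and nothing in the set shows chain length moving this assay. The expectation is therefore a step no larger than the scatter, with the number estimated to stay close to that of compound 1. Compound 4 is expected to give about 12000 nM in this assay, within 5000 nM to 30000 nM, which is an expected step of a 1.2-fold lower number from compound 1 to compound 4 (0.09 log units; within the scatter).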

Compound 4, half-maximal inhibitory concentration: 9200 nM
Beside the measured number, compound 4's estimate is 1.3-fold (0.12 log units) above it; the measured number falls inside the stated range.
By their numbers in this assay, from the lowest: compounds 2, 3, 4 and 1 (each within the scatter of the next, the first and the last beyond it).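

Butyl to pentyl gives the first measured pair in which the alkoxymethyl arm alone changes, and the step (a 1.6-fold lower number from compound 1 to compound 4 (0.20 log units; within the scatter)) stays within the scatter. At this place, four bonds along the chain from an oxygen on a saturated carbon, methyl in place of hydrogen therefore does not separate the two compounds in this assay. This single pair gives no direction for chain length, and it shows only that this one added carbon is accommodated without a step beyond the scatter.

No measurement bears on what underlies this step.

Still open, on these data alone, is whether a longer chain such as hexyl, or an amine or carboxylic acid at the end of the chain, would move the number beyond the scatter. Also open, as far as these compounds go, is whether the butyl to pentyl step reads the same on a core carrying methoxy.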